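The source may report more compounds than this note shows. Statements on the series, on what has been measured and on what is new or still open speak of the compounds shown alone.

Of the compounds shown here, two have been measured so far in a functional assay on SK-N-AS cells (Homo sapiens) for antiproliferative activity, with a stated time of 72 h (on this read-out higher numbers stand for weaker inhibition and lower numbers for stronger inhibition), and their numbers sit close together. There compound 2 (`CN(C)c1ccc(C(=O)N(CCC(=O)NCc2ccc(Cl)cc2)Cc2ccc(C(=O)NO)cc2)cc1`) gives 390 nM and compound 1 (`Cc1ccc(NC(=O)CCN(Cc2ccc(C(=O)NO)cc2)C(=O)c2ccccc2)cc1`) gives 620 nM so the two values lie within the usual scatter of each other. Compound 3 (`Cc1ccc(NC(=O)CCN(Cc2ccc(C(=O)NO)cc2)C(=O)c2ccc(N(C)C)cc2)cc1`) keeps the rest of compound 2 and changes one piece, with 4-methylphenyl in place of 4-chlorobenzyl on an amide-type nitrogen is the full count of that change. Among the measured compounds shown here, compound 1 also carries 4-methylphenyl, but it differs from compound 2 in more than one place, so no measured pair shows this swap alone. No shift beyond the scatter is therefore expected in this assay and no direction can be claimed. The expected step is a 1.2-fold higher number from compound 2 to compound 3 (0.06 log units; within the scatter) and it stays within the scatter. Compound 3 is estimated at 450 nM (expected range 200 nM to 1000 nM).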

Compound 3, half-maximal inhibitory concentration: 400 nM
Estimate against measurement, compound 3: 1.1-fold (0.05 log units) above, within the range that was stated.
By their numbers in this assay, from the lowest: compounds 2, 3 and 1 (each within the scatter of the next).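

In this assay the change from 4-chlorobenzyl to 4-methylphenyl on an amide-type nitrogen can now be seen on its own: it gives a 1.0-fold higher number from compound 2 to compound 3 (0.01 log units; within the scatter) and so does not separate the two groups at this position. Compound 3 also isolates a second change, dimethylamino in place of hydrogen on an aromatic carbon, which gives a 1.6-fold lower number from compound 1 to compound 3 (0.19 log units; within the scatter) and likewise shows no shift that can be told from the scatter. No measurement at hand bears on these results.

Still open, going by these compounds, is whether a cyclohexyl group, a plain alkyl chain or an amine on that amide-type nitrogen would move the number beyond the scatter. The same question stands for a methoxy group or a carboxylic acid in place of dimethylamino on the aromatic carbon.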